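Swapping pyridine attachment in a paw-edema series

A few compounds are considered here, and "the series" means these few. Any claim that something is new, unique, unknown or untested is made for them only; others in the source may bear on it.

Three related compounds have been tested in a functional assay on the whole organism (strain Charles Foster albino) for inhibition, with Rattus norvegicus as the target, read by paw edema, with stated times of 30 min and 3 h, at a dose of 50 mg/kg by the oral route; on this read-out lower numbers stand for less inhibition and higher numbers for more inhibition at the one dose given (going by the name of the read-out). Compound 1, `COc1ccc(OC)c(C2CC(c3ccccn3)=NN2c2ccccc2)c1`, gives 27% in this assay. Compound 2, `COc1ccc(OC)c(C2CC(c3cccnc3)=NN2c2ccccc2)c1`, gives 24% in this assay. Compound 3, `CN(C)c1ccc(C2CC(c3ccccn3)=NN2c2ccccc2)cc1`, gives 35% in this assay, the highest of the three numbers, though its distance from compound 1 lies within the scatter and only its distance from compound 2 lies beyond it.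

Compound 1 and compound 2 differ in one place: pyridin-3-yl in place of pyridin-2-yl on a carbon with a double bond to nitrogen. This change gave a number 3 percentage points lower from compound 1 to compound 2 (within the scatter). The difference between the core of compound 1 and the core of compound 3 is not broken down here.

Compound 4, `CN(C)c1ccc(C2CC(c3cccnc3)=NN2c2ccccc2)cc1`, has not yet been measured in this assay. Its relation to compound 3 is pyridin-3-yl in place of pyridin-2-yl on a carbon with a double bond to nitrogen. Around the place, the description differs only in wording: for compound 1 and compound 2 the ring atom bears a large group, for compound 3 and compound 4 a group of 9 heavy atoms, so the two changes are the same kind of change rather than the same. Among the compounds with values here, because the only measured example of this kind of change gave a number 3 percentage points lower from compound 1 to compound 2 (within the scatter), compound 4 is expected to give about 32%, with a range estimated from 22% to 42%. The expected step is therefore a number 3 percentage points lower from compound 3 to compound 4 (within the scatter), a size that would stay within the scatter.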

Compound 4, a percentage reported as inhibition, in the whole organism at one dose (the size of the read-out at that dose, not a potency): 34%
Beside the measured number, compound 4's estimate is 2 percentage points below it; the range from low to high includes it.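

In this assay, within the data shown here, putting pyridin-3-yl in place of pyridin-2-yl on the core of compound 3 gave a number 1 percentage points lower from compound 3 to compound 4 (within the scatter) and so left no step that can be told apart from the usual spread of repeated measurements. On the two cores shown, this change therefore behaves alike, with neither step large enough to read as a real difference, and the two steps do not differ from each other: the same change on two cores in this assay, a number 3 percentage points lower (within the scatter) from compound 1 to compound 2 and a number 1 percentage points lower (within the scatter) from compound 3 to compound 4, 2 percentage points apart, within the scatter of two such steps. This shows only that swapping the pyridine attachment made no readable difference on these two cores at the one oral dose given; it does not show that the same would hold on a third core, and it says nothing about potency, since a percentage at a single dose is not a potency.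

The compounds shown leave open how pyridin-4-yl, or a plain phenyl group with no ring nitrogen, would read on the carbon with a double bond to nitrogen. They also leave open whether the change would still make so little difference on a core carrying a carboxylic acid or a longer chain in place of the groups seen here.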